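An ethoxy group added to an unreadable pair

The compounds below may be only part of what the source reports. "The series", "measured", "known", "first", "only" and "open" are said of these compounds alone.

Compound 1 `COc1cc(-n2ncnc2-c2ccccc2)cc(OC)c1OC` gives > 10000 nM as a limit
Compound 2 `COc1cc(-n2ncnc2-c2ccc(F)cc2)cc(OC)c1OC` gives > 10000 nM as a limit

Both entries come from a functional assay on MCF7 cells (Homo sapiens) for antiproliferative activity, read by MTT assay, with a stated time of 72 h (on this read-out higher numbers stand for weaker inhibition and lower numbers for stronger inhibition), and neither is a number. Compound 1 stands at a limit of > 10000 nM in this assay and so has no exact place on the scale. Compound 2 sits at a limit as well, and the limit of > 10000 nM in this assay, at which 2 of the 2 values shown sit, is all that the two measurements provide.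

Among the compounds with values here, the only measured step is a step that the two limits leave unreadable from compound 1 to compound 2 and it therefore offers no size to carry over. Compound 3 `CCOc1ccccc1-c1ncnn1-c1cc(OC)c(OC)c(OC)c1` has not been measured, and it keeps the core of compound 1 with one change: ethoxy in place of hydrogen on an aromatic carbon. Within the data shown here, no measured step involves an ethoxy group, so the data give no direction for this change. The expectation is therefore that compound 3 shows no clear gain in this assay over compound 1, and may well end at a limit too. The estimated step is a step that the limit leaves unreadable from compound 1 to compound 3 and it carries little confidence. For compound 3 the estimated half-maximal inhibitory concentration is 12000 nM with an expected range from 3000 nM to 40000 nM in this read-out.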

Compound 3, half-maximal inhibitory concentration: > 10000 nM
Compound 3: no number, only a limit; the forecaster's own chance of this, stated with the estimate: 70%; the middle value is on the limit's open side.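

In this assay compound 3 gives > 10000 nM, which is a limit and not a number. With compound 1 also at a limit, no new step can be read between compound 1 and compound 3: the limit of > 10000 nM in this assay, at which 3 of the 3 values shown sit.

The compounds shown leave open whether the fluoro or ethoxy group changes activity at all, since none has an exact value.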